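Swapping a large sulfonyl substituent for methyl

This account rests on a few compounds, and the source may have more. Where it says the series, first, only, none or still open, it means among the compounds named here.

Compound 1 `COc1ccc(S(=O)(=O)Nc2ccc3oc(-c4ccccc4)nc3c2)cc1`: 91000 nM
Compound 2 `CCc1ccc(S(=O)(=O)Nc2ccc3oc(-c4ccccc4)nc3c2)cc1`: 81000 nM

Within the data shown here, compound 2 stands level with compound 1 in an ADME assay on HEK293 cells (Homo sapiens) for cytotoxicity, read by resazurin assay, with a stated time of 48 h (a higher number here means that more compound is tolerated, a lower number that less compound is tolerated), and these two are the only numbers so far. Compound 3 `CS(=O)(=O)Nc1ccc2oc(-c3ccccc3)nc2c1` carries methyl in place of 4-ethylphenyl on a sulfonyl sulfur, with methyl in place of 4-ethylphenyl on a sulfonyl sulfur as the full count of that difference from compound 2. Among the measured compounds shown here, the only measured step is a 1.1-fold lower number from compound 1 to compound 2 (0.05 log units; within the scatter) and it kept the aromatic ring that compound 3 loses, so it is a weak guide and points in no direction. The expected change is a 1.1-fold higher number from compound 2 to compound 3 (0.05 log units; within the scatter) and nothing beyond the scatter is predicted. For compound 3 the estimate is 90000 nM as the expected value, with a likely range from 35000 nM to 230000 nM given so little data.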

Compound 3, half-maximal cytotoxic concentration: > 100000 nM
Compound 3: no number, only a limit (the forecaster's own chance of this, stated with the estimate: 30%); middle value at least 1.1-fold (0.04 log units) from the limit.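

Replacing the whole aromatic ring on the sulfonyl sulfur with methyl does not lower the tolerated concentration, giving an at least 1.2-fold higher number from compound 2 to compound 3 (0.09 log units; that floor lies within the scatter) and an at least 1.0-fold higher number from compound 1 to compound 3 (0.04 log units; that floor lies within the scatter). This shows that neither 4-ethylphenyl nor 4-methoxyphenyl at this position is needed for the low cytotoxicity seen in this assay. Compound 3 gives > 100000 nM, which is a limit and not a number: the limit of > 100000 nM in this assay, at which 1 of the 3 values shown sits.

As far as these compounds go, how far the true value of compound 3 lies past that limit remains open. So does whether a longer chain such as propyl, or an amine, on the sulfonyl sulfur would be tolerated equally well.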